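Swapping a five-membered ring on a fused core

The source may report more compounds than this note shows. Statements on the series, on what has been measured and on what is new or still open speak of the compounds shown alone.

Measured so far:
compound 1, `CCCc1c(OC)nc2nc(-c3noc(C)n3)cn2c1C` — 5 mg/kg 
compound 2, `CCc1c(OC)nc2nc(-c3nnco3)cn2c1C` — > 50 mg/kg 
compound 3, `CCOC(=O)c1csc(-c2cn3c(C)c(CC)c(OC)nc3n2)n1` — > 50 mg/kg 

All three were tested in a functional assay on the whole organism with Rattus norvegicus as the target; a higher number here means that more compound is needed for the effect, a lower number that less compound is needed. Compound 1 gives 5 mg/kg in this assay. Compound 2 reaches only a limit of the assay, > 50 mg/kg. Compound 3 likewise stops at a limit, > 50 mg/kg. So compound 2 stands at the limit of > 50 mg/kg in this assay, at which 2 of the 3 values shown sit, and no number for it is known.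

Compound 4, `CCc1c(OC)nc2nc(-c3n[nH]c(C)n3)cn2c1C`, is not yet measured. It differs from compound 2 in one place: 5-methyl-1H-1,2,4-triazol-3-yl in place of 1,3,4-oxadiazol-2-yl on an aromatic carbon. Within the data shown here, no measured pair differing in one place is available, so the size of this step cannot be read from the data. Among the measured compounds shown here, since compound 2 sits at a limit, the only step that can be seen at all is toward a lower dose, and the step from compound 2 to compound 4 is expected to be an at least 1.6-fold lower number from compound 2 to compound 4 (0.22 log units; that floor lies within the scatter). Compound 4 is estimated at 30 mg/kg, in a range from 8 mg/kg to 100 mg/kg.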

Compound 4, minimum effective dose: > 50 mg/kg
Compound 4 gave a limit, no number; the forecaster's own chance of this, stated with the estimate: 45%; middle value at least 1.6-fold (0.22 log units) from the limit.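

Compound 2 and compound 4 both end at a limit rather than a number, so no step between them can be read: the limit of > 50 mg/kg in this assay, at which 3 of the 4 values shown sit.

The compounds shown leave open whether 5-methyl-1H-1,2,4-triazol-3-yl and 1,3,4-oxadiazol-2-yl on the shared core differ at all in this assay.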